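Two limit values and a furanyl analogue awaiting measurement

The source may report more compounds than this note shows. Statements on the series, on what has been measured and on what is new or still open speak of the compounds shown alone.

Measured so far:
compound 1 `Cc1ccc(-c2nc(N)c3nc(-c4ccccc4)sc3n2)o1`: > 30000 nM
compound 2 `Nc1nc(-c2cccc(O)c2)nc2sc(-c3ccco3)nc12`: > 30000 nM

In a functional assay on CHO cells for antagonist activity at adenosine receptor A2b (Homo sapiens), read by cAMP accumulation, with a stated time of 10 min (a higher number here means a weaker inhibitor, a lower number a stronger inhibitor), compound 2 gives > 30000 nM, which is a limit of the assay and not a number. Compound 1 also returns only a limit; in this assay compound 1 gives > 30000 nM. Among the compounds with values here, both values shown thus sit at the limit of > 30000 nM in this assay, at which 2 of the 2 values shown sit, so nothing among the measured compounds ranks one over the other, and no step between measured compounds that differ in one place can be drawn from them.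

Compound 3 `Cc1ccc(-c2nc(N)c3nc(-c4ccco4)sc3n2)o1` is not yet measured. It differs from compound 2 by 5-methylfuran-2-yl in place of 3-hydroxyphenyl on an aromatic carbon. Compound 1 already carries the 5-methylfuran-2-yl group at the same place on its own shared core and reaches only the limit, so the change is not expected to move compound 3 beyond the scatter in either direction. The step from compound 2 to compound 3 is expected to be a number no higher from compound 2 to compound 3 (the limit leaves the size open) in this assay. Compound 3 is therefore estimated at 30000 nM, within a range of 8000 nM to 100000 nM, with the most likely outcome again a limit rather than a number.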

Compound 3, half-maximal inhibitory concentration: > 30000 nM
Compound 3: no number, only a limit; the forecaster's own chance of this, stated with the estimate: 70%; the middle value lies on the limit itself.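

In this assay compound 3 gives > 30000 nM as a limit, not a number. The steps to compound 3 from compound 1 and compound 2 cannot be read because no value shown is a number: the limit of > 30000 nM in this assay, at which 3 of the 3 values shown sit. The compounds shown leave open whether any group on the shared core gives a readable number in this assay at all.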